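Changing the Sulfonamide Cap on a Shared Thiourea Core

A few compounds are considered here, and "the series" means these few. Any claim that something is new, unique, unknown or untested is made for them only; others in the source may bear on it.

Compound 1 `CC(=O)NS(=O)(=O)c1ccc(N/C(S)=N\c2ccnc3cc(C(F)(F)F)ccc23)cc1`: 28300 nM
Compound 2 `N=C(N)NS(=O)(=O)c1ccc(N/C(S)=N\c2ccnc3cc(C(F)(F)F)ccc23)cc1`: 24300 nM
Compound 3 `O=S(=O)(Nc1ncccn1)c1ccc(N/C(S)=N\c2ccnc3cc(C(F)(F)F)ccc23)cc1`: 29100 nM

Three compounds share one core and differ only in the group attached to a sulfonamide nitrogen. In a functional assay on HT-1080 cells (Homo sapiens) for antiproliferative activity, read by sulforhodamine B assay, with a stated time of 48 h (on this read-out higher numbers stand for weaker inhibition and lower numbers for stronger inhibition), compound 1 gives 28300 nM, compound 2 gives 24300 nM and compound 3 gives 29100 nM. The steps between them are small: a 1.2-fold lower number from compound 1 to compound 2 (0.07 log units; within the scatter), a 1.0-fold higher number from compound 1 to compound 3 (0.01 log units; within the scatter) and a 1.2-fold higher number from compound 2 to compound 3 (0.08 log units; within the scatter). Compound 3 therefore sits alongside the other two, with its steps to compound 1 and compound 2 both within the scatter, so none of the three can be called stronger or weaker than another.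

Compound 4 `COc1cc(NS(=O)(=O)c2ccc(N/C(S)=N\c3ccnc4cc(C(F)(F)F)ccc34)cc2)nc(OC)n1` is the next member. Its difference from compound 3 is 2,6-dimethoxypyrimidin-4-yl in place of pyrimidin-2-yl on a sulfonamide nitrogen. Each of the three measured steps changed this same position, exchanging an acetyl, a guanidine-type group and a pyrimidin-2-yl, and none of them moved the number beyond the scatter in this assay. Adding two methoxy groups and shifting the attachment point of the pyrimidine is a change at the same place, and the expectation is again no step beyond the scatter: a 1.0-fold lower number from compound 3 to compound 4 (0.00 log units; within the scatter). For compound 4 the estimated value in this assay is 29000 nM, expected to fall between 12000 nM and 70000 nM.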

Compound 4, half-maximal inhibitory concentration: 29500 nM
Compound 4: middle estimate off by 1.0-fold (0.01 log units), on the low side, and the stated range covers the measured number.
By their numbers in this assay, from the lowest: compounds 2, 1, 3 and 4 (each within the scatter of the next).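

Compound 4 extends what this position tolerates. Here 2,6-dimethoxypyrimidin-4-yl, with its two added methoxy groups and a different attachment point on the ring, replaces pyrimidin-2-yl on the sulfonamide nitrogen, and this assay shows a 1.0-fold higher number from compound 3 to compound 4 (0.01 log units; within the scatter) as the outcome. The same bulkier ring also leaves the read-out within the scatter when set against the ringless guanidine-type group (a 1.2-fold higher number from compound 2 to compound 4 (0.08 log units; within the scatter)) and against acetyl (a 1.0-fold higher number from compound 1 to compound 4 (0.02 log units; within the scatter)), so all four groups, which range from a small open chain to a substituted aromatic ring, give numbers that cannot be told apart. No supporting measurement is available to explain this flat result.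

These compounds leave open whether any group on this sulfonamide nitrogen can move the number beyond the scatter, for example a carboxylic acid, a basic amine on a longer chain or a simple methyl group. Because all four share the rest of the structure, they also cannot show whether changing the trifluoromethyl group, for instance to a chlorine atom or a methoxy group, would matter more.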